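Amino on the pyridin-3-yl group of compound 2

The source may hold more compounds than are shown below. What is called first, only, known or untested is meant among the compounds shown, and "the series" means these compounds.

Compound 2 `C[C@H](NC(=O)c1ncccn1)c1ccc(NC(=O)N2CC(c3cccnc3)C2)cc1` gives 930000 nM in a physicochemical assay for solubility, read by LC-MS, in phosphate buffer, with a stated time of 24 h, at pH 6.8 (a lower number here means a less soluble compound, a higher number a more soluble compound), the highest of the two plain numbers in the set. Compound 1 `C[C@H](NC(=O)c1cccc(F)c1)c1ccc(NC(=O)N2CC(c3cccnc3)C2)cc1` gives 11000 nM in this assay. Compound 3 `C[C@H](NC(=O)[C@@H]1CCCN1C)c1ccc(NC(=O)N2CC(c3cccnc3)C2)cc1` reaches only a limit of this assay, > 1000000 nM, and is no number (the limit of > 1000000 nM in this assay, at which 1 of the 3 values shown sits). The steps of an 85-fold higher number from compound 1 to compound 2 (1.93 log units; beyond the scatter) and an at least 90-fold higher number from compound 1 to compound 3 (1.95 log units; beyond the scatter) both swap the group on the carbonyl carbon, and the step of an at least 1.0-fold higher number from compound 2 to compound 3 (0.03 log units; that floor lies within the scatter) does the same. Compound 4 `C[C@H](NC(=O)c1ncccn1)c1ccc(NC(=O)N2CC(c3ccc(N)nc3)C2)cc1` differs from compound 2 in another place: amino in place of hydrogen on an aromatic carbon. Within the data shown here, none of the measured steps alters this ring, so they set no size for the change; they show only that compound 2 already sits near the top of the range covered here. For compound 4 in this assay no step beyond the scatter is expected, a 1.1-fold higher number from compound 2 to compound 4 (0.03 log units; within the scatter), with a fair chance that only a limit is reported. Compound 4 is estimated at 1000000 nM, between 400000 nM and 2500000 nM.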

Compound 4, solubility: 300000 nM
Estimate against measurement, compound 4: 3.3-fold (0.52 log units) above; measured number outside the range, below it.
By their numbers in this assay, from the lowest: compound 1; then compound 4; then compound 2. At a limit, above all of these: compound 3.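

Among these compounds, the earlier steps all changed the group on the carbonyl carbon, so this is the first size attached to a change on the pyridin-3-yl group: in this assay, a 3.1-fold lower number from compound 2 to compound 4 (0.49 log units; beyond the scatter). The place next to the ring nitrogen is therefore not silent in this read-out, and a single amino group there lowers the number by a modest step, beyond the scatter. Nothing shown here bears on why the number falls with this change.

From the compounds shown here alone, whether a methyl, a methoxy or a dimethylamino group in the same place moves the number in the same direction, and by a similar size, remains open. Also open, going by these compounds, is the size of the same amino step with 3-fluorophenyl on the carbonyl carbon, as in compound 1, rather than pyrimidin-2-yl.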